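The compounds below may be only part of what the source reports. "The series", "measured", "known", "first", "only" and "open" are said of these compounds alone.

Measured so far:
Compound 1 `O=C(OCCCCCCO)OCCc1ccc(O)c(O)c1`: > 50000 nM
Compound 2 `CCCCCCOC(=O)OCCc1ccc(OCc2ccccc2)c(OCc2ccccc2)c1`: "not determined" (no result reported)

In an ADME assay on MRC5 cells (Homo sapiens) for inhibition, read by MTT assay, with a stated time of 72 h (a lower number here means a stronger inhibitor, a higher number a weaker inhibitor), compound 1 gives > 50000 nM, which is a limit of the assay and not a number. Compound 2 has no reported result, so compound 1 is the only reference point.

Compound 3 `CCCCCCCCCCCCOC(=O)OCCc1ccc(O)c(O)c1` keeps the core of compound 1 and alters the end of its chain: hexyl in place of hydroxy on a saturated chain carbon, six bonds along the chain from an oxygen next to a carbonyl group. This places hexyl in place of hydroxy on a saturated chain carbon, six bonds along the chain from an oxygen next to a carbonyl group. For the measured compounds named here, no pair of measured compounds shows what such a change does, so any forecast is uncertain. A moderate move towards stronger inhibition in this assay is expected, though compound 3 may also end at the limit. The estimated change is an at least 1.6-fold lower number from compound 1 to compound 3 (0.22 log units; that floor lies within the scatter). The expected value for compound 3 is 30000 nM, with an estimated range of 12000 nM to 50000 nM.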

Compound 3, half-maximal inhibitory concentration: 12400 nM
The estimate for compound 3 lay 2.4-fold (0.38 log units) above the measured number, and the stated range covers the measured number.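

Hexyl in place of hydroxy on a saturated chain carbon, six bonds along the chain from an oxygen next to a carbonyl group, gives the first readable step at this position in this assay: there is an at least 4.0-fold lower number from compound 1 to compound 3 (0.60 log units; beyond the scatter). Compound 3 gives a real number, 12400 nM, so the end of this chain can affect the read-out even though the core of compound 1 stays unchanged. Compound 1 gives > 50000 nM, which is a limit and not a number, and the step is only a floor because of this limit: the limit of > 50000 nM in this assay, at which 1 of the 3 values shown sits.

This single change removes the hydroxy and adds carbon atoms together, so the compounds shown cannot tell which of the two matters. On these data alone, how an amine or a carboxylic acid at the chain end, or a longer chain, would read remains open.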